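The source may report more compounds than this note shows. Statements on the series, on what has been measured and on what is new or still open speak of the compounds shown alone.

Working notes on the series built around the core of compound 1 `COc1ccc(/C=N/NC(=O)Nc2ccc(Oc3ccnc(-c4nncn4CCN(C)C)c3)c(F)c2)c(OC)c1`. In a functional assay on MKN-45 cells (Homo sapiens) for cytotoxicity, read by MTT assay, with a stated time of 72 h (on this read-out higher numbers stand for weaker inhibition and lower numbers for stronger inhibition), compound 1 gives 1680 nM. Compound 2 `CN(C)CCn1cnnc1-c1cc(Oc2ccc(NC(=O)N/N=C/c3ccc(O)c(Br)c3)cc2F)ccn1` gives 1860 nM, and compound 3 `CN(C)CCn1cnnc1-c1cc(Oc2ccc(NC(=O)N/N=C/c3cccc(Cl)c3Cl)cc2F)ccn1` gives 51 nM. Of these three numbers compound 1 stands second highest; its nearest neighbour is compound 2 and its furthest is compound 3.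

The two measured steps that change the same position read as follows: a 1.1-fold higher number from compound 1 to compound 2 (0.04 log units; within the scatter), and a 33-fold lower number from compound 1 to compound 3 (1.52 log units; beyond the scatter). Compound 3 also sets the distance from compound 2 through a 36-fold lower number from compound 2 to compound 3 (1.56 log units; beyond the scatter).

Compound 4 `CN(C)CCn1cnnc1-c1cc(Oc2ccc(NC(=O)N/N=C/c3ccc(O)cc3O)cc2F)ccn1` is not yet measured. It differs from compound 1 by 2,4-dihydroxyphenyl in place of 2,4-dimethoxyphenyl on a carbon with a double bond to nitrogen. The change keeps two oxygen substituents on the aromatic ring and adds hydrogen-bond donors, which makes compound 2, whose 3-bromo-4-hydroxyphenyl likewise carries a hydroxyl, the closer precedent; that step stayed within the scatter. The large drop seen toward compound 3 came with a 2,3-dichlorophenyl and carries no oxygen, so it is not taken as a guide here. The expectation for compound 4 in this assay is therefore a step of about a 1.2-fold higher number from compound 1 to compound 4 (0.08 log units; within the scatter), in practice no step beyond the scatter. Compound 4 is expected to give about 2000 nM, with a range from 900 nM to 4500 nM.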

Compound 4, half-maximal inhibitory concentration: 2860 nM
Beside the measured number, compound 4's estimate is 1.4-fold (0.16 log units) below it, and the stated range covers the measured number.
By their numbers in this assay, from the lowest: compound 3; then compounds 1, 2 and 4 (each within the scatter of the next).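

Replacing the 2,4-dimethoxyphenyl with 2,4-dihydroxyphenyl on a carbon with a double bond to nitrogen brings in hydrogen-bond donors and removes heavy atoms, yet in this assay the measured result is a 1.7-fold higher number from compound 1 to compound 4 (0.23 log units; within the scatter) and, against the bromo-hydroxy analogue, a 1.5-fold higher number from compound 2 to compound 4 (0.19 log units; within the scatter) with no separation among these three compounds. The step of a 56-fold higher number from compound 3 to compound 4 (1.75 log units; beyond the scatter) places compound 4 on the same side of the large gap as compound 1 and compound 2, so all three aryl groups carrying oxygen now stand apart from the 2,3-dichlorophenyl of compound 3, and the bromine of compound 2 shows that a halogen alone does not bring a compound to the level of compound 3. Nothing at hand explains the gap or why hydroxyl and methoxy groups read alike at this position.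

The compounds shown do not separate the presence of two chlorines from the absence of oxygen on the ring, nor the substitution pattern from the nature of the substituents. An unsubstituted phenyl or a 2,3-dimethoxyphenyl at this position would bear directly on both questions.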